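The compounds below may be only part of what the source reports. "The series", "measured", "known", "first", "only" and "open" are said of these compounds alone.

Compound 1 `CN1CCC[C@@H]1Cn1nc(Cc2ccc(C(C)(C)C)cc2)c2ccccc2c1=O` carries a tert-butyl group on its outer benzene ring. In an assay for binding affinity to Alpha-1B adrenergic receptor (Homo sapiens) (on this read-out lower numbers stand for stronger inhibition and higher numbers for weaker inhibition), compound 1 gives only a limit, > 1990 nM, so its true strength is not known beyond that (the limit of > 1990 nM in this assay, at which 1 of the 3 values shown sits). Two related compounds with chlorine in place of that group bind measurably: compound 2 `O=c1c2ccccc2c(Cc2ccc(Cl)cc2)nn1C[C@H]1CCCN1CCCCCc1ccc(OCCCN2CCCCCC2)cc1` gives 50.1 nM in this assay, and compound 3 `CN1CCC(Cn2nc(Cc3ccc(Cl)cc3)c3ccccc3c2=O)C1` gives 79.4 nM. Compound 4 `COC(=O)c1ccc(Cc2nn(C[C@H]3CCCN3C)c(=O)c3ccccc23)cc1` matches compound 1 except for (methoxycarbonyl in place of tert-butyl on an aromatic carbon), methoxycarbonyl in place of tert-butyl on an aromatic carbon. Among the compounds with values here, no measured pair shows this exchange, so its size cannot be read from the data; the change is expected to move toward stronger inhibition, though how far is uncertain. Compound 4 is therefore estimated at 600 nM, likely between 100 nM and 4000 nM, an expected step of an at least 3.3-fold lower number from compound 1 to compound 4 (0.52 log units; beyond the scatter).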

Compound 4, inhibition constant: > 1990 nM
Compound 4 was reported as a limit; the forecaster's own chance of this, stated with the estimate: 35%; middle value at least 3.3-fold (0.52 log units) from the limit.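

In this assay, within the data shown here, compound 1 and compound 4 each give only a limit, so no step between them can be read: the limit of > 1990 nM in this assay, at which 2 of the 4 values shown sit.
Going by these compounds, how strongly either compound truly binds, and what methoxycarbonyl in place of tert-butyl changes, stays open.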